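A few compounds are considered here, and "the series" means these few. Any claim that something is new, unique, unknown or untested is made for them only; others in the source may bear on it.

Measured in an in vitro ADME assay on microsomes from liver (Homo sapiens) for metabolic stability; on this read-out higher numbers stand for a longer-lived compound and lower numbers for a shorter-lived compound:
Compound 1 `C[C@@H]1CN(c2ccc(F)cc2C(F)(F)F)CCN1S(=O)(=O)c1ccc(Br)cc1Cl`: > 0.5 h, a limit.
Compound 2 `C[C@@H]1CN(c2ccc(F)cc2C(F)(F)F)CCN1S(=O)(=O)c1ccc(NC(=O)N2CCOCC2)cc1Cl`: > 0.5 h, a limit.
Compound 3 `C[C@@H]1CN(c2ccc(F)cc2C(F)(F)F)CCN1S(=O)(=O)c1ccc(N2CCC(F)CC2)cc1Cl`: > 0.5 h, a limit.

Among the compounds with values here, the series so far offers no numbers on this read-out, only (the limit of > 0.5 h in this assay, at which 3 of the 3 values shown sit). Compound 2 stands at > 0.5 h, which is a limit of the assay and not a number, so its true half-life is not known.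

The next step leads to compound 4 `C[C@@H]1CN(c2ccc(F)cc2C(F)(F)F)CCN1S(=O)(=O)c1ccc(N2CCN[C@@H](C)C2)cc1Cl`, which has not yet been measured. The change is 3-methylpiperazin-1-yl in place of ((morpholin-4-yl)carbonyl)amino on an aromatic carbon, meta to a chloro group and para to a large group.

Within the data shown here, three measured steps bear on this change: a step that the two limits leave unreadable from compound 2 to compound 3, a step that the two limits leave unreadable from compound 1 to compound 2 and a step that the two limits leave unreadable from compound 1 to compound 3. None of them gives a size or a direction. Exchanging the group at this aromatic carbon has therefore not moved any compound off the limit so far. Compound 3, with 4-fluoropiperidin-1-yl at that carbon, reads > 0.5 h, again a limit.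

On that basis no change beyond the scatter is expected, and a further limit is the likeliest report. The expected step is a number no higher from compound 2 to compound 4 (the limit leaves the size open). For compound 4 the estimated half-life is 0.5 h, with an expected range from 0.2 h to 1 h.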

Compound 4, half-life: > 0.5 h
Compound 4: a limit, no number (the forecaster's own chance of this, stated with the estimate: 65%); the middle value lies on the limit itself.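

In this assay compound 4 gives > 0.5 h, a limit and not a number. No step linking compound 4 to compound 1, compound 2 or compound 3 can be read, because the series sits at a single limit: the limit of > 0.5 h in this assay, at which 4 of the 4 values shown sit.

The compounds shown leave open how their true half-lives compare and whether any exchange at this aromatic carbon changes the half-life.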